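This account rests on a few compounds, and the source may have more. Where it says the series, first, only, none or still open, it means among the compounds named here.

Notes on the amine series. Compound 1 `CCN(CC)CC(O)COc1ccc2oc(=O)cc(C)c2c1` gives 0.0052 ug/mL in a functional assay on ileum for antagonist activity at histamine H1 receptor (Cavia porcellus), tested at 0.1 mg/mL; on this read-out lower numbers stand for an effect already at smaller amounts and higher numbers for an effect only at larger amounts of compound. Compound 2 `Cc1cc(=O)oc2ccc(OCC(O)CN3CCCCC3)cc12` gives 0.0055 ug/mL in this assay, and compound 3 `Cc1cc(=O)oc2ccc(OCC(O)CN3CCN(C)CC3)cc12` gives 0.0058 ug/mL. Compound 3 sits at the top of the three numbers, but its steps to the other two are small: a 1.1-fold higher number from compound 1 to compound 3 (0.05 log units; within the scatter) and a 1.1-fold higher number from compound 2 to compound 3 (0.02 log units; within the scatter), so on these data the three amines cannot be told apart.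

Compound 4 `Cc1cc(=O)oc2ccc(OCC(O)CN3CCN(c4ccccc4)CC3)cc12` is the next member: phenyl in place of methyl on an amine nitrogen in a ring. Going by the values given here, no measured pair covers a change at this nitrogen; the steps that come closest are those that exchange the whole amine, a 1.1-fold higher number from compound 1 to compound 2 (0.02 log units; within the scatter) and a 1.1-fold higher number from compound 2 to compound 3 (0.02 log units; within the scatter), and both stayed within the scatter. A phenyl in place of the methyl is a larger change than any of those, so some movement in either direction cannot be ruled out, but nothing measured points to it. Compound 4 is therefore expected to give about 0.008 ug/mL in this assay, with a range of 0.003 ug/mL to 0.025 ug/mL, the expected step being a 1.4-fold higher number from compound 3 to compound 4 (0.14 log units; within the scatter).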

Compound 4, half-maximal effective concentration: 0.0052 ug/mL
For compound 4 the middle estimate is 1.5-fold (0.19 log units) above the measured one, within the range that was stated.
By their numbers in this assay, from the lowest: compounds 1, 4, 2 and 3 (each within the scatter of the next).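

At the amine nitrogen in the ring, phenyl in place of methyl gives a 1.1-fold lower number from compound 3 to compound 4 (0.05 log units; within the scatter) in this assay, the first step read at this position rather than by exchanging the whole amine. The step stays within the scatter even though phenyl is much the larger of the two groups, so compound 3 and compound 4 cannot be told apart and this position accepts an aromatic ring of carbon only with no measurable change in this read-out. No measurement at hand bears on why the number holds with either group.

As far as these compounds go, whether a benzyl group, a longer chain or a carboxylic acid on this nitrogen would also stay within the scatter remains open. With only methyl and phenyl shown here, it also remains open whether any group at this position can move the number.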